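Removing the chloro from the benzyl group of compound 2

This account rests on a few compounds, and the source may have more. Where it says the series, first, only, none or still open, it means among the compounds named here.

Measured so far:
compound 1, `CCCSc1nc(N/N=C/c2ccc(N(C)C)cc2)c2nnn(Cc3ccccc3)c2n1`: 20000 nM
compound 2, `CCCSc1nc(N/N=C(\C)c2ccccc2O)c2nnn(Cc3cccc(Cl)c3)c2n1`: 13000 nM

Of the compounds shown here, two have been tested in a functional assay on ECa-109 cells (Homo sapiens) for antiproliferative activity, read by MTT assay, with a stated time of 72 h; a higher number here means a weaker inhibitor, a lower number a stronger inhibitor. Compound 1 gives 20000 nM, and compound 2 gives 13000 nM. The gap between these two numbers lies within the usual scatter of repeated measurements, so compound 2 cannot be set apart from compound 1 on the data at hand; both are weak inhibitors in this assay .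

Compound 3, `CCCSc1nc(N/N=C(\C)c2ccccc2O)c2nnn(Cc3ccccc3)c2n1`, is not yet measured. It differs from compound 2 in one place: hydrogen in place of chloro on an aromatic carbon. Cut one bond further out, the change reads 3-chlorobenzyl to benzyl, while the rest of the shared core is kept. Going by the values given here, no step between two measured compounds isolates this difference, so nothing measured here tells how large its effect is. A small step in this assay is expected, if any, toward a weaker inhibitor. The step from compound 2 to compound 3 is estimated at a 1.2-fold higher number from compound 2 to compound 3 (0.09 log units; within the scatter), and compound 3 is expected to give 16000 nM, with a range from 6000 nM to 40000 nM.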

Compound 3, half-maximal inhibitory concentration: 11100 nM
The estimate for compound 3 lay 1.4-fold (0.16 log units) above the measured number; low and high end bracket the measured number.
By their numbers in this assay, from the lowest: compounds 3, 2 and 1 (each within the scatter of the next).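

Taking the chloro off the 3-chlorobenzyl group gives a 1.2-fold lower number from compound 2 to compound 3 (0.07 log units; within the scatter) in this assay, the first reading of this change in a matched pair. With the rest of the structure held fixed, the chloro at this position can be lost without a change that can be told from the scatter, and compound 3 stays a weak inhibitor like compound 2. Nothing given here bears on why the step is so small.

This single pair cannot tell whether the position is insensitive in general or only to this one exchange, since it tests nothing but chloro and hydrogen. As far as these compounds go, a methoxy group, an amine or a carboxylic acid on this aromatic ring remains open, as does whether any such group could bring a stronger inhibitor.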